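Working notes: compounds 1 to 3 measured, compound 4 pending

The source may hold more compounds than are shown below. What is called first, only, known or untested is meant among the compounds shown, and "the series" means these compounds.

Measured so far in a functional assay on RAW264.7 cells (Mus musculus) for inhibition, read by Griess assay, with stated times of 1 h and 24 h; a higher number here means a weaker inhibitor, a lower number a stronger inhibitor:
- compound 1, `Cc1noc(CC2OC(=O)c3ccccc32)n1`: a limit of the assay only, > 10000 nM.
- compound 2, `O=C1OC(Cc2nc(-c3ccc(-c4ccccc4)cc3)no2)c2ccccc21`: again only a limit of the assay, > 10000 nM.
- compound 3, `COCCCCOc1ccc(C(O)C2OC(=O)c3c(OC)cc(OC)cc32)cc1`: 8210 nM.

Among the compounds with values here, compound 3 holds the only numeric value among the three. The other two sit at the limit of > 10000 nM in this assay, at which 2 of the 3 values shown sit, so nothing orders them relative to compound 3 beyond the fact that compound 3 returned a number at all, and that number is itself a weak one. Within the data shown here, no pair of measured compounds differs in one place, so no measured step is available to lean on.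

Compound 4, `COc1cc(OC)c2c(c1)C(C(O)c1ccc(OCc3ccc(OC(F)F)cc3)cc1)OC2=O`, is the next structure in the series. It differs from compound 3 as follows: 4-(difluoromethoxy)phenyl in place of 3-methoxypropyl on a saturated chain carbon bound to an oxygen on an aromatic ring. Among the measured compounds shown here, with no measured step of this kind, the expectation for compound 4 rests only on where compound 3 stands. The step from compound 3 to compound 4 in this assay is expected to be a 1.8-fold lower number from compound 3 to compound 4 (0.26 log units; within the scatter), leaning toward a somewhat stronger inhibitor but not clearly beyond the scatter. Compound 4 is therefore estimated at 4500 nM in this assay, within 1200 nM to 15000 nM, with a real chance that only a limit is returned.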

Compound 4, half-maximal inhibitory concentration: 5030 nM
For compound 4 the middle estimate is 1.1-fold (0.05 log units) below the measured one; low and high end bracket the measured number.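

In this assay, within the data shown here, the exchange of 3-methoxypropyl for 4-(difluoromethoxy)phenyl, on a saturated chain carbon bound to an oxygen on an aromatic ring, gives a 1.6-fold lower number from compound 3 to compound 4 (0.21 log units; within the scatter) and is the first measured step. The read-out at this position therefore stays within the scatter when a group with no ring gives way to one carrying a six-membered aromatic ring of carbon only, so this place accepts that exchange without a clear gain or loss. The step also shows that this exchange alone does not separate the two compounds, and neither compound moves out of the weak range of the values shown.

As far as these compounds go, whether another group at this place, such as a terminal amine, a carboxylic acid or a longer chain, would carry the read-out beyond the scatter remains open, since this single step is the only one available. Compound 1 and compound 2 return only a limit of the assay, and neither can be ordered against compound 3 or compound 4: the limit of > 10000 nM in this assay, at which 2 of the 4 values shown sit.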